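Para-substituent swap on the aryl ketone of compound 1

A few compounds are considered here, and "the series" means these few. Any claim that something is new, unique, unknown or untested is made for them only; others in the source may bear on it.

Measured compounds:
compound 1 `COc1cc(-c2nnc3n2NC(c2ccco2)C(C(=O)c2ccc(Cl)cc2)S3)cc(OC)c1OC` gives 67800 nM in a functional assay on PC-3 cells (Homo sapiens) for cytotoxicity, read by MTT assay, with a stated time of 48 h; a lower number here means a stronger inhibitor, a higher number a weaker inhibitor
compound 2 `COc1cc(-c2nnc3n2NC(c2cccs2)C(C(=O)c2ccc(C)cc2)S3)cc(OC)c1OC` gives 5090 nM in this assay
compound 3 `COc1cc(-c2nnc3n2NC(c2cccs2)C(C(=O)c2ccccc2)S3)cc(OC)c1OC` gives 86300 nM in this assay

In this assay compound 1 and compound 3 lie within the scatter of each other; compound 2 gives a lower number than both, beyond the scatter.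

Compound 4 `COc1ccc(C(=O)C2Sc3nnc(-c4cc(OC)c(OC)c(OC)c4)n3NC2c2ccco2)cc1` differs from compound 1 by methoxy in place of chloro on an aromatic carbon. Among the compounds with values here, the only step through a single change is a 17-fold higher number from compound 2 to compound 3 (1.23 log units; beyond the scatter), which removes a group from that same ring position rather than exchanging one group for another, so it bears on the new compound only loosely. Keeping a substituent in that position, no step beyond the scatter is expected; the estimated step is a 1.5-fold lower number from compound 1 to compound 4 (0.18 log units; within the scatter). Compound 4 is therefore expected near 45000 nM, with a range of 12000 nM to 170000 nM.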

Compound 4, half-maximal inhibitory concentration: > 100000 nM
Compound 4 was reported as a limit (the forecaster's own chance of this, stated with the estimate: 10%); middle value at least 2.2-fold (0.34 log units) from the limit.
By their numbers in this assay, from the lowest: compound 2; then compounds 1 and 3 (each within the scatter of the next). At a limit, above all of these: compound 4.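

In this assay compound 4 gives > 100000 nM, which is a limit and not a number. Within the data shown here, this is the first exchange of one group for another at this position, and methoxy in place of chloro brings no lower number: an at least 1.4-fold higher number from compound 1 to compound 4 (0.16 log units; that floor lies within the scatter). The true size of that step stays unresolved: the limit of > 100000 nM in this assay, at which 1 of the 4 values shown sits.

Still open, from the compounds shown here alone, is whether methyl on the core of compound 1 would give a number like that of compound 2. Also open, going by these compounds, is how an amine or a carboxylic acid at this position would read.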